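Swapping the oxazole for a pyrazole on a weak inhibitor

The compounds below may be only part of what the source reports. "The series", "measured", "known", "first", "only" and "open" are said of these compounds alone.

Compound 2 `Cc1noc(C)c1-c1nn(Cc2ccc(C(=O)NC3CC3)cc2)c(=O)c2ccccc12` was tested in a functional assay on HeLa cells (Homo sapiens) for antiproliferative activity, read by MTT assay, with a stated time of 72 h; a lower number here means a stronger inhibitor, a higher number a weaker inhibitor. In this assay compound 2 reaches only the limit > 100000 nM, not a number. Compound 3 `Cc1noc(C)c1-c1nn(Cc2ccc(C(=O)N3CCCCC3)cc2)c(=O)c2ccccc12` likewise gives only the limit > 100000 nM in this assay. Among the measured compounds shown here, the one measured step, a step that the two limits leave unreadable from compound 2 to compound 3, therefore cannot be read, because the limit of > 100000 nM in this assay, at which 2 of the 3 values shown sit, hides whatever size it has. Compound 1 `CN1CCC(NC(=O)c2ccc(Cn3nc(-c4cnn(C)c4)c4ccccc4c3=O)cc2)CC1` carries the same 1-methyl-1H-pyrazol-4-yl group as compound 4 but a different amide. In this assay compound 1 gives 28500 nM, a number rather than a limit.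

Compound 4 `Cn1cc(-c2nn(Cc3ccc(C(=O)NC4CC4)cc3)c(=O)c3ccccc23)cn1` differs from compound 2 by 1-methyl-1H-pyrazol-4-yl in place of 3,5-dimethyl-1,2-oxazol-4-yl on an aromatic carbon. For the measured compounds named here, no measured step follows exactly this change, so nothing here says how large its effect should be. Going by the values given here, the only guide is that compound 1, with the entering group, gives a number, while compound 2 does not. Compound 4 is therefore expected to land around 60000 nM, within 20000 nM to 150000 nM, an estimated step of an at least 1.6-fold lower number from compound 2 to compound 4 (0.22 log units; that floor lies within the scatter), though a limit remains quite possible.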

Compound 4, half-maximal inhibitory concentration: 40000 nM
For compound 4 the middle estimate is 1.5-fold (0.18 log units) above the measured one; the measured number falls inside the stated range.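

On this aromatic carbon of the shared core, 1-methyl-1H-pyrazol-4-yl in place of 3,5-dimethyl-1,2-oxazol-4-yl gives, in this assay, an at least 2.5-fold lower number from compound 2 to compound 4 (0.39 log units; beyond the scatter). That size is only a floor, because compound 2 gives a limit and not a number: the limit of > 100000 nM in this assay, at which 2 of the 4 values shown sit. With the pyrazole fixed, cyclopropyl in place of 1-methylpiperidin-4-yl on an amide-type nitrogen gives a 1.4-fold higher number from compound 1 to compound 4 (0.15 log units; within the scatter), so these two amides cannot be told apart in this assay.

The compounds shown leave open which part of the swap matters, as the ring atoms and the methyl groups change together. Also open, on these data alone, is what a pyrazol-4-yl without the methyl group, or an aminomethyl or carboxylic acid group at this position, would give, and whether the piperidin-1-yl amide also yields a number when paired with the pyrazole.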